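Closing the amine side chain into a ring

A few compounds are considered here, and "the series" means these few. Any claim that something is new, unique, unknown or untested is made for them only; others in the source may bear on it.

Of the compounds shown here, three have been measured in an assay for binding affinity to Alpha-1A adrenergic receptor (Homo sapiens); a higher number here means a weaker inhibitor, a lower number a stronger inhibitor. Compound 1 `CN1CCC[C@@H]1Cn1nc(Cc2ccc(F)cc2)c2ccccc2c1=O` gives 63.1 nM. Compound 2 `CN(C)CCn1nc(Cc2ccc(Cl)cc2)c2ccccc2c1=O` gives 158 nM. Compound 3 `CN1CCC[C@@H]1Cn1nc(CCc2ccccc2)c2ccccc2c1=O` gives 200 nM.

Compound 2 has the second highest number of the three; its gap to compound 3 lies within the scatter, while compound 1 sits well below it. Compound 4 `CN1CCCCC(n2nc(Cc3ccc(Cl)cc3)c3ccccc3c2=O)C1` is not yet measured. It differs from compound 2 by 1-methylazepan-3-yl in place of 2-(dimethylamino)ethyl on an aromatic nitrogen. Among the compounds with values here, the only one-place step known, a 3.2-fold higher number from compound 1 to compound 3 (0.50 log units; beyond the scatter), changes the group on the other side of the core and so says nothing about the amine side chain. Compound 1 and compound 2 differ in two places at once, so their two values cannot be split into parts. Within the data shown here, with no direct precedent, no step beyond the scatter is expected: compound 4 is estimated at 130 nM, between 40 nM and 400 nM, an expected step of a 1.2-fold lower number from compound 2 to compound 4 (0.08 log units; within the scatter).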

Compound 4, inhibition constant: 158 nM
Compound 4: the middle estimate sits 1.2-fold (0.08 log units) below what was measured, within the range that was stated.
By their numbers in this assay, from the lowest: compound 1; then compounds 2, 4 and 3 (each within the scatter of the next).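

Within the data shown here, replacing the open-chain 2-(dimethylamino)ethyl group on the aromatic nitrogen with the 1-methylazepan-3-yl ring gives no change at the digits printed from compound 2 to compound 4 (within the scatter) in this assay and this is the first direct reading of a change at this position. Here, the amine-bearing group can be either an open chain or a seven-membered ring, with the two values staying within the scatter. Nothing available explains why these two groups read alike.

The compounds shown leave open how this position would respond to a group with no amine, such as a carboxylic acid. They also do not show how a 1-methylpiperidin-3-yl group would compare with 1-methylazepan-3-yl on the same core.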